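This account rests on a few compounds, and the source may have more. Where it says the series, first, only, none or still open, it means among the compounds named here.

Compound 1 `CN1[C@@H]2c3[nH]c4ccccc4c3C[C@H]1[C@H](C#N)N1[C@@H](CNC(=O)c3ccc(Cl)cc3)c3[nH]c4ccccc4c3C[C@@H]21` and compound 2 `CCc1ccc(C(=O)NC[C@H]2c3[nH]c4ccccc4c3C[C@H]3[C@H]4c5[nH]c6ccccc6c5C[C@@H]([C@H](C#N)N23)N4C)cc1` share one core and differ only in the group on the amide's aromatic ring. Going by the values given here, in a functional assay on MCF7 cells (Homo sapiens) for cytotoxicity, read by MTT assay, with a stated time of 72 h (on this read-out higher numbers stand for weaker inhibition and lower numbers for stronger inhibition), compound 1 gives 610 nM, the highest of the two numbers so far, and compound 2 gives 170 nM. Among the compounds with values here, the only measured step, a 3.6-fold lower number from compound 1 to compound 2 (0.55 log units; beyond the scatter), shows that a change at this ring can move the number beyond the scatter.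

Compound 3 `CN1[C@@H]2c3[nH]c4ccccc4c3C[C@H]1[C@H](C#N)N1[C@@H](CNC(=O)/C=C/c3ccccc3)c3[nH]c4ccccc4c3C[C@@H]21` has not yet been measured. It differs from compound 1 by 2-phenylethenyl in place of 4-chlorophenyl on a carbonyl carbon. The step of a 3.6-fold lower number from compound 1 to compound 2 (0.55 log units; beyond the scatter) is the only one that bears on this change, and it concerns a substituent on the ring rather than the exchange of the whole 4-chlorophenyl for 2-phenylethenyl, so it can guide only loosely. Since that one step lowered the number, a modest lowering is expected for compound 3 as well, though a step of either direction within a wide range cannot be ruled out. The estimated step is a 1.5-fold lower number from compound 1 to compound 3 (0.18 log units; within the scatter). For compound 3 the estimate in this assay is 400 nM, with a range from 120 nM to 1500 nM.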

Compound 3, half-maximal inhibitory concentration: 7190 nM
Beside the measured number, compound 3's estimate is 18-fold (1.25 log units) below it, and the stated range ends below it.
By their numbers in this assay, from the lowest: compound 2; then compound 1; then compound 3.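

The group on the carbonyl carbon matters more than the earlier pair could show: compounds 1 and 2 differ only by a substituent on the aromatic ring, whereas in this assay replacing 4-chlorophenyl with 2-phenylethenyl gives a 12-fold higher number from compound 1 to compound 3 (1.07 log units; beyond the scatter), a much larger step than a 3.6-fold lower number from compound 1 to compound 2 (0.55 log units; beyond the scatter). The picture is the same when compound 3 is set against the more active of the earlier two, with a 42-fold higher number from compound 2 to compound 3 (1.63 log units; beyond the scatter). Keeping an aromatic ring in this group is therefore not enough to hold the activity in this cell assay, since compound 3 still has one six-membered aromatic ring yet has a clearly higher number, meaning weaker inhibition, than both compound 1 and compound 2.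

Nothing measured here gives a reason for this loss. From the compounds shown here alone, the change also combines two differences, the added double bond and the missing ring substituent, so their shares remain open: a plain phenyl on the carbonyl carbon, a saturated 2-phenylethyl group, or 2-phenylethenyl carrying a chloro or ethyl group on its ring would be needed to tell them apart.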